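Shortening the chain on the ring nitrogen

The source may hold more compounds than are shown below. What is called first, only, known or untested is meant among the compounds shown, and "the series" means these compounds.

Measured so far:
compound 1 `Brc1cccc2c1nnn2CC1CCCC1` — 30 nM
compound 2 `CCCCn1nnc2c(Br)cccc21` — 60 nM
compound 3 `CCn1nnc2c(Br)cccc21` — 2240 nM

In a functional assay on cells for positive allosteric modulation of metabotropic glutamate receptor 2 (Homo sapiens), read by fluorescence and calcium flux, with a stated time of 30 min (a lower number here means that less compound is needed, a higher number that more compound is needed for the effect), compound 3 stands at the highest number of the three. The step of a 75-fold higher number from compound 1 to compound 3 (1.87 log units; beyond the scatter) and the step of a 37-fold higher number from compound 2 to compound 3 (1.57 log units; beyond the scatter) both run the same way, whereas a 2.0-fold higher number from compound 1 to compound 2 (0.30 log units; within the scatter). Compound 4 `Cn1nnc2c(Br)cccc21` continues this cut by one more carbon: hydrogen in place of methyl on a saturated chain carbon bound to an aromatic nitrogen. The two earlier shortenings bear directly on this move and were both large; a further rise is therefore expected, though a smaller one, since only a single carbon leaves, giving an expected 2.7-fold higher number from compound 3 to compound 4 (0.43 log units; beyond the scatter). For compound 4 the estimate is 6000 nM, within a range of 2500 nM to 20000 nM, with some chance that only a limit is reported.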

Compound 4, half-maximal effective concentration: > 5000 nM
Compound 4 was reported as a limit (the forecaster's own chance of this, stated with the estimate: 20%); the middle value is on the limit's open side.
By their numbers in this assay, from the lowest: compounds 1 and 2 (each within the scatter of the next); then compound 3. At a limit, above all of these: compound 4.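

In this assay, hydrogen in place of methyl continues the trend of the earlier shortenings, giving an at least 2.2-fold higher number from compound 3 to compound 4 (0.34 log units; beyond the scatter). The gaps to the two compounds with larger groups are wider still, with an at least 83-fold higher number from compound 2 to compound 4 (1.92 log units; beyond the scatter) and an at least 160-fold higher number from compound 1 to compound 4 (2.22 log units; beyond the scatter). The value of compound 4 is a limit, so these steps give only minimum sizes: the limit of > 5000 nM in this assay, at which 1 of the 4 values shown sits.

Going by these compounds, whether a longer chain than that of compound 2 keeps the number low remains open. So does the effect of an amine or a carboxylic acid at the end of the chain.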